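The compounds below may be only part of what the source reports. "The series", "measured", "known", "first", "only" and "open" are said of these compounds alone.

Of the compounds shown here, two have been measured in a functional assay on Calu-3 cells (Homo sapiens) for cytotoxicity, read by WST assay, with a stated time of 72 h; on this read-out lower numbers stand for stronger inhibition and higher numbers for weaker inhibition. Compound 1 `O=[N+]([O-])c1ccc(-c2cc(-c3ccc4[nH]ccc4c3)on2)cc1` gives 25800 nM in this assay, the lowest of the two numbers. Compound 2 `COc1ccc(-c2cc(-c3c(Cl)c4ccccc4n3C)no2)cc1`, which is built on a different framework, gives 60900 nM; this is a higher number than that of compound 1, and the gap between the two is beyond the usual scatter, so compound 1 is the more potent of the pair.

The next compound keeps the core of compound 1 and alters only one substituent. Compound 3 `COC(=O)c1ccc(-c2cc(-c3ccc4[nH]ccc4c3)on2)cc1` differs from compound 1 in that (methoxycarbonyl in place of nitro on an aromatic carbon). Within the data shown here, no measured pair shows what this particular exchange does on this assay, so the size and direction of the step can only be guessed: the two groups are alike in having no ring, one double bond outside aromatic rings, no hydrogen-bond donors and two acceptors, so no step beyond the scatter is expected in this assay, and the expected move from compound 1 to compound 3 is a 1.2-fold higher number from compound 1 to compound 3 (0.07 log units; within the scatter). For compound 3 the estimated value in this assay is 30000 nM, with a range from 10000 nM to 90000 nM.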

Compound 3, half-maximal inhibitory concentration: > 100000 nM
Compound 3 was reported as a limit; the forecaster's own chance of this, stated with the estimate: 15%; at least 3.3-fold (0.52 log units) between middle value and limit.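

Among these compounds, compound 1 and compound 3 differ in one place only, the group on an aromatic carbon of the six-membered aromatic ring of carbon only, para to a large group, so this pair is the first to show what a change at that position does in this assay. Putting methoxycarbonyl in place of nitro there gives an at least 3.8-fold higher number from compound 1 to compound 3 (0.58 log units; beyond the scatter), so the read-out responds to this exchange even though the two groups have the same counts of rings, outside double bonds, hydrogen-bond donors and hydrogen-bond acceptors. The reading for compound 3 is a limit of the assay and not a number, so the true size of the step stays unknown: the limit of > 100000 nM in this assay, at which 1 of the 3 values shown sits.

A single pair cannot tell which difference between nitro and methoxycarbonyl matters, and it gives no trend across groups at this position. An amine, a carboxylic acid or a simple methyl group at the same place would be needed to show whether nitro is unusual here or methoxycarbonyl is, and whether the same exchange behaves alike on another core.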